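Cyclopropylamino to 3-aminophenyl on the shared core: solubility outlook

The compounds below may be only part of what the source reports. "The series", "measured", "known", "first", "only" and "open" are said of these compounds alone.

Within the data shown here, compound 1 `c1cc(-c2ccnc3ccc(NC4CC4)nc23)ccn1` is the only member of the set with a read number in a physicochemical assay for solubility, read by HPLC, using the shake flask method, measured as kinetic solubility, with a stated time of 20 h, at pH 6.5, tested at 200 uM; a lower number here means a less soluble compound, a higher number a more soluble compound: compound 1 gives 90000 nM. Compound 2 `NS(=O)(=O)c1cccc(-c2ccc3nccc(-c4cccnc4)c3n2)c1` reaches only a limit in this assay, < 5000 nM. Compound 3 `NS(=O)(=O)c1cccc(-c2ccc3nccc(-c4cn[nH]c4)c3n2)c1` likewise sits at a limit, < 5000 nM. Among the measured compounds shown here, the single measured step, a step that the two limits leave unreadable from compound 2 to compound 3, is therefore unreadable and cannot guide the present change. Compound 4 `Nc1cccc(-c2ccc3nccc(-c4ccncc4)c3n2)c1` differs from compound 1 as follows: 3-aminophenyl in place of cyclopropylamino on an aromatic carbon. The change enlarges the substituent from a three-membered ring to a six-membered aromatic ring. Direct evidence on this move is lacking, but the two analogues bearing aromatic substituents both sit at the limit of < 5000 nM in this assay, at which 2 of the 3 values shown sit, which points to a drop in solubility beyond the scatter rather than a gain. Compound 4 is accordingly expected to fall well under compound 1, with a step estimated at a 13-fold lower number from compound 1 to compound 4 (1.11 log units; beyond the scatter). The estimate for compound 4 is 7000 nM, with a range from 1500 nM to 35000 nM, and a real chance that only a limit is reported.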

Compound 4, solubility: < 5000 nM
Compound 4: no number, only a limit; the forecaster's own chance of this, stated with the estimate: 40%; at least 1.4-fold (0.14 log units) between middle value and limit.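

In this assay, among these compounds, placing 3-aminophenyl instead of cyclopropylamino on this aromatic carbon, next to the ring nitrogen, gives an at least 18-fold lower number from compound 1 to compound 4 (1.25 log units; beyond the scatter), the first readable step in the set and a large one. Compound 4 gives only a limit, < 5000 nM. Compound 2, compound 3 and compound 4 each carry a six-membered aromatic ring at this place and share one limit, while compound 1 alone keeps a read number: the limit of < 5000 nM in this assay, at which 3 of the 4 values shown sit.

Among the compounds shown here, no step among the compounds at the limit can be read, so the full size of the drop and any effect of the other ring substituents stay open. Also open, from the compounds shown here alone, is whether a morpholine ring or a carboxylic acid at this place would keep a read number in this assay.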